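Cytotoxicity notes: thiazole series, compound 2 to compound 3

A few compounds are considered here, and "the series" means these few. Any claim that something is new, unique, unknown or untested is made for them only; others in the source may bear on it.

Measured so far:
- compound 1 `Cc1cc(Br)cc(OC(c2ccc(Cl)cc2)c2cnc(NC(=O)OC(C)(C)C)s2)c1` gives > 50000 nM in an ADME assay on HepG2 2.2.15 cells (Homo sapiens) for cytotoxicity; a higher number here means that more compound is tolerated, a lower number that less compound is tolerated
- compound 2 `COCCNc1ncc(C(Oc2ccc3cc(Br)ccc3c2)c2ccc(Cl)cc2)s1` is recorded as "not toxic" (no number reported) in this assay

For compound 1 the value > 50000 nM is a limit of the assay and not a number. Compound 2 has no single number in this assay; it is reported only as not toxic, so its place on the scale is known merely as tolerated at the concentrations tested. Going by the values given here, no step between two measured compounds exists, so there is no measured reference for how a change at the amino nitrogen moves the half-maximal cytotoxic concentration.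

Compound 3 `O=C(Nc1ncc(C(Oc2ccc3cc(Br)ccc3c2)c2ccc(Cl)cc2)s1)c1ccccc1` has not yet been measured. It differs from compound 2 by benzoyl in place of 2-methoxyethyl on a nitrogen on an aromatic ring. Because compound 1 sits at the limit of > 50000 nM in this assay, at which 1 of the 2 values shown sits, and compound 2 is described as not toxic, the expectation for compound 3 in this assay is no step beyond the scatter, most probably again a limit rather than a number. Compound 3 is estimated at 50000 nM, with a range from 20000 nM to 100000 nM.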

Compound 3, half-maximal cytotoxic concentration: "not toxic" (no number reported)
Compound 3 has no reported number here, and the estimate cannot be compared.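

In this assay compound 2 is recorded as "not toxic" (no number reported) and compound 3 as "not toxic" (no number reported), so no step can be read between them. Left open is whether benzoyl in place of 2-methoxyethyl moves the half-maximal cytotoxic concentration at all, since the only figure shown is a limit: the limit of > 50000 nM in this assay, at which 1 of the 3 values shown sits.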